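Anilino replacements on the shared core: compound 2 to compound 4

The source may hold more compounds than are shown below. What is called first, only, known or untested is meant among the compounds shown, and "the series" means these compounds.

Measured so far:
- compound 1 `CC(C(=O)NCc1ccc(C(F)(F)F)nc1NC1CCCCC1)c1ccc(NS(C)(=O)=O)c(F)c1`: 20.4 nM
- compound 2 `CC(C(=O)NCc1ccc(C(F)(F)F)nc1Nc1ccccc1)c1ccc(NS(C)(=O)=O)c(F)c1`: 59.6 nM
- compound 3 `CC(C(=O)NCc1ccc(C(F)(F)F)nc1Nc1ccc(F)cc1)c1ccc(NS(C)(=O)=O)c(F)c1`: 39.2 nM

All three compounds were run in a functional assay on CHO-K1 cells for antagonist activity at transient receptor potential cation channel subfamily V member 1 (Homo sapiens), read by FLIPR; a higher number here means a weaker inhibitor, a lower number a stronger inhibitor. Compound 2 gives the highest of the three numbers; its nearest neighbour is compound 3, at a 1.5-fold lower number from compound 2 to compound 3 (0.18 log units; within the scatter), and the step to compound 1 is the only one beyond the scatter, a 2.9-fold higher number from compound 1 to compound 2 (0.47 log units; beyond the scatter). Compound 3 sits a 1.9-fold higher number from compound 1 to compound 3 (0.28 log units; within the scatter) from compound 1.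

Compound 4 `CC(C(=O)NCc1ccc(C(F)(F)F)nc1NCc1cccnc1)c1ccc(NS(C)(=O)=O)c(F)c1` has not been measured in this assay. It differs from compound 2 in one place: (pyridin-3-yl)methyl in place of phenyl on a nitrogen on an aromatic ring.

Of the measured steps, only the change from compound 1 to compound 2 touches the same nitrogen on an aromatic ring, and it exchanged cyclohexyl for phenyl; the step from compound 2 to compound 3 only exchanges hydrogen for fluoro on the phenyl. Among the measured compounds shown here, neither step inserts a methylene or brings a ring with a hetero atom to this nitrogen, so there is no measured step of the same kind. Both replacements at this position stayed within or just beyond the scatter, which suggests the position tolerates change of this sort. For compound 4 a step of a 1.2-fold lower number from compound 2 to compound 4 (0.08 log units; within the scatter) is therefore expected, meaning no change beyond the scatter, with the range left wide in both directions. Compound 4 is estimated at 50 nM in this assay, between 18 nM and 150 nM.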

Compound 4, inhibition constant: "not active" (no number reported)
Nothing numeric was reported for compound 4; no gap can be computed for the estimate.
By their numbers in this assay, from the lowest: compounds 1, 3 and 2 (each within the scatter of the next, the first and the last beyond it).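

In this assay, among the compounds shown here, compound 4 is reported only as "not active", without a number, so no step from compound 2 to compound 4 can be read. Nothing shown accounts for this result. The compounds shown leave open whether the added methylene, the ring hetero atom, or both together go with this outcome.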